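The source may report more compounds than this note shows. Statements on the series, on what has been measured and on what is new or still open speak of the compounds shown alone.

Three compounds have been measured in an assay on U2OS cells for activation of nuclear factor erythroid 2-related factor 2 (Homo sapiens), read by beta-arrestin recruitment, with a stated time of 6 h; on this read-out lower numbers stand for an effect already at smaller amounts and higher numbers for an effect only at larger amounts of compound:

Compound 1, `O=S(=O)(/C=C/c1ccccn1)c1ccccc1F`, gives 1050 nM.
Compound 2, `O=S(=O)(/C=C/c1ncccc1F)c1ccccc1F`, gives 176 nM.
Compound 3, `O=S(=O)(/C=C/c1ccccn1)c1ccc(F)cc1`, gives 3100 nM.

Compounds 1 and 2 share one core, while compound 3 is built on another; the difference between the core of compound 1 and the core of compound 3 is not broken down here. Compound 3 has the highest number of the three, and its gaps to compound 1 and to compound 2 both lie beyond the usual scatter of this assay.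

For the measured compounds named here, only one structural change has been measured on its own, the step from compound 1 to compound 2: fluoro in place of hydrogen on an aromatic carbon. That step gave a 6.0-fold lower number from compound 1 to compound 2 (0.78 log units; beyond the scatter).

Compound 4, `O=S(=O)(/C=C/c1ncccc1F)c1ccc(F)cc1`, has not yet been measured. Going by the values given here, it differs from compound 3 by fluoro in place of hydrogen on an aromatic carbon, which is the same change as the one from compound 1 to compound 2, now made on the core of compound 3. Whether the change moves the number by a similar amount on this second core cannot be read from the compounds at hand, since the change has been seen only once. If it does carry over, compound 4 is expected to show a 6.0-fold lower number from compound 3 to compound 4 (0.78 log units; beyond the scatter), a step of roughly the earlier size because the same change produced a 6.0-fold lower number from compound 1 to compound 2 (0.78 log units; beyond the scatter). Compound 4 is therefore estimated at 520 nM, with a likely range from 200 nM to 1500 nM.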

Compound 4, half-maximal effective concentration: 542 nM
The estimate for compound 4 lay 1.0-fold (0.02 log units) below the measured number, and the stated range covers the measured number.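

In this assay, putting fluoro in place of hydrogen on an aromatic carbon gave a 5.7-fold lower number from compound 3 to compound 4 (0.76 log units; beyond the scatter). This is the second time the change has been seen, and on this second core its size matched what it did on the first, so in this small series the step carried over from one core to the other: the same change on two cores in this assay, a 6.0-fold lower number (0.78 log units; beyond the scatter) from compound 1 to compound 2 and a 5.7-fold lower number (0.76 log units; beyond the scatter) from compound 3 to compound 4, 1.0-fold (0.02 log units) apart, within the scatter of two such steps

This agreement rests on one change, at one place on the ring, on just two closely related cores and in a single assay, so it does not show that the step would hold on a more different core, and it says nothing about why fluoro lowers the number.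

The compounds shown leave open whether another group at the same place, such as chloro, methyl, methoxy or an amine, would lower the number as well, or whether this result is particular to fluoro. They also leave open whether the step would keep its size on a core carrying something other than fluoro on the second ring, for instance a nitrile or a carboxylic acid.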